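The compounds below may be only part of what the source reports. "The series", "measured", "known", "first", "only" and "open" are said of these compounds alone.

Compound 1 `CCOC(=O)c1cc2ccc(OCc3ccccc3)cc2oc1=O`: 7.01 nM
Compound 2 `CCOC(=O)c1cc2ccc(OCc3cccc(Cl)c3)cc2oc1=O`: 61.2 nM

In an in vitro assay on BTI-TN-5B1-4 cells for inhibition of Amine oxidase [flavin-containing] B (Homo sapiens), read by fluorescence, with a stated time of 15 min (a higher number here means a weaker inhibitor, a lower number a stronger inhibitor), compound 2 gives 61.2 nM, the highest of the two numbers; its nearest neighbour is compound 1, which gives 7.01 nM. Within the data shown here, the one measured step, an 8.7-fold higher number from compound 1 to compound 2 (0.94 log units; beyond the scatter), concerns only the chloro on the aromatic ring. Compound 3 `CCOC(=O)c1cc2ccc(OC3CCCCCC3)cc2oc1=O` carries cycloheptyl in place of 3-chlorobenzyl on an oxygen on an aromatic ring. Among the measured compounds shown here, no measured step covers the exchange of an aromatic ring for a seven-membered saturated ring, so the direction of this step cannot be read from the data and the range must be wide. Compound 3 is expected to give about 150 nM, between 20 nM and 1500 nM. That expectation corresponds to a step of a 2.5-fold higher number from compound 2 to compound 3 (0.39 log units; beyond the scatter).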

Compound 3, half-maximal inhibitory concentration: 21.5 nM
Estimate against measurement, compound 3: 7.0-fold (0.84 log units) above; low and high end bracket the measured number.
By their numbers in this assay, from the lowest: compound 1; then compound 3; then compound 2.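

In this assay a saturated ring is tolerated on the oxygen: cycloheptyl in place of 3-chlorobenzyl gives a 2.8-fold lower number from compound 2 to compound 3 (0.45 log units; beyond the scatter) and cycloheptyl in place of benzyl gives a 3.1-fold higher number from compound 1 to compound 3 (0.49 log units; beyond the scatter) at the same place. An aromatic ring at this position is therefore not required, although the unsubstituted benzyl of compound 1 remains the lowest of the three. No available evidence accounts for this order.

Open, as far as these compounds go, is whether a cyclohexyl ring or an open pentyl chain on the oxygen follows cycloheptyl. Also open, from the compounds shown here alone, is whether a carboxylic acid in place of the ethyl ester changes this order.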